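Free hydroxyl versus silyl ether on two related cores

The compounds below may be only part of what the source reports. "The series", "measured", "known", "first", "only" and "open" are said of these compounds alone.

Measured in an ADME assay on DU-145 cells (Homo sapiens) for cytotoxicity, read by MTT assay, with a stated time of 72 h; on this read-out lower numbers stand for stronger inhibition and higher numbers for weaker inhibition:
- compound 1 `COc1ccc(C2=C(c3cc(OC)c(OC)c(OC)c3)C(=O)C(O)C2)cc1` gives > 100 ug/mL, a limit of the assay rather than a number.
- compound 2 `COc1ccc(OC)c(C2=C(c3cc(OC)c(OC)c(OC)c3)C(=O)CC2O[SiH2]C(C)(C)C)c1` gives 100 ug/mL.
- compound 3 `COc1ccc(C2=C(c3cc(OC)c(OC)c(OC)c3)C(=O)C(O[SiH2]C(C)(C)C)C2)cc1` gives 28 ug/mL.

Compound 3 and compound 1 share one core and differ in a single place: a hydrogen atom in place of a group of 5 heavy atoms (4 carbon, 1 silicon; no ring), on an oxygen on a saturated carbon. That change produced an at least 3.5-fold higher number from compound 3 to compound 1 (0.55 log units; beyond the scatter), so the free hydroxyl compound is the weaker of the pair, and its value sits at the limit of > 100 ug/mL in this assay, at which 1 of the 3 values shown sits.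

Compound 2 carries the same silyl group as compound 3 but on a different core; the difference between the two cores is not broken down here. In this assay compound 2 has the highest of the two numbers that were read, and its gap from compound 3 lies beyond the usual scatter.

Compound 4 `COc1ccc(OC)c(C2=C(c3cc(OC)c(OC)c(OC)c3)C(=O)CC2O)c1` has not yet been measured. It is the free hydroxyl counterpart of compound 2: a hydrogen atom in place of a group of 5 heavy atoms (4 carbon, 1 silicon; no ring), on an oxygen on a saturated carbon. For the measured compounds named here, this is the same change as the one from compound 3 to compound 1, made at a place described in the same words. The step from compound 2 to compound 4 is therefore expected to be a 2.5-fold higher number from compound 2 to compound 4 (0.40 log units; beyond the scatter), an expectation resting on an at least 3.5-fold higher number from compound 3 to compound 1 (0.55 log units; beyond the scatter). Compound 4 is expected to give about 250 ug/mL, with a likely range from 80 ug/mL to 800 ug/mL, and there is a good chance that only a limit is reported.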

Compound 4, half-maximal inhibitory concentration: > 100 ug/mL
Compound 4: no number, only a limit; the forecaster's own chance of this, stated with the estimate: 70%; the middle value is on the limit's open side.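

Set side by side, the swap of the silyl group for a hydrogen atom on the oxygen reads as follows in this assay: the same change on two cores in this assay, an at least 3.5-fold higher number (0.55 log units; beyond the scatter) from compound 3 to compound 1 and a number no lower (the limit leaves the size open) from compound 2 to compound 4; the limit leaves it open whether they differ

On the core of compound 2, the step is a number no lower from compound 2 to compound 4 (the limit leaves the size open), so the direction seen with compound 3 and compound 1 is not contradicted on this second core, and in both pairs the silyl ether is not the weaker partner. Compound 4 gives > 100 ug/mL, which is a limit of the assay and not a number, so the size of its step cannot be read, and nothing shows that the change is worth the same amount on both cores.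

Neither free hydroxyl compound has a readable number, so compound 1 and compound 4 cannot be ranked against each other, and limits make up a large share of this small set: the limit of > 100 ug/mL in this assay, at which 2 of the 4 values shown sit.

The compounds shown also leave open whether the silyl group itself matters or whether any larger group on that oxygen would do the same, and a methyl ether, an acetate ester or an amine in place of the hydroxyl would help to tell these apart.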